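The source may hold more compounds than are shown below. What is called first, only, known or untested is meant among the compounds shown, and "the series" means these compounds.

In an ADME assay on the whole organism (strain Balb) for pharmacokinetics, with Mus musculus as the target, read by LC-MS, at a dose of 10 mg/kg by the oral route (on this read-out higher numbers stand for higher oral bioavailability and lower numbers for lower oral bioavailability), compound 1 `CCc1ccc(Cl)cc1-n1cc(-c2ncnn3cccc23)cc1C(N)=O` gives 1%, while compound 2 `CCc1ccc(Cl)cc1-n1cc(-c2cc(N)ncn2)cc1C(N)=O` gives 50%, the higher of the two numbers by a gap well beyond the usual scatter. Compound 3 `CCc1ccc(Cl)cc1-n1cc(-c2cc(NC)ncn2)cc1C(N)=O` alters compound 2 in one place: methyl in place of hydrogen on a nitrogen on an aromatic ring, with methyl in place of hydrogen on a nitrogen on an aromatic ring. Going by the values given here, no measured pair shows this change, so any forecast is loose. A small drop in this assay is expected, probably not beyond the scatter. The estimated step is a number 8 percentage points lower from compound 2 to compound 3 (within the scatter). For compound 3 the expected value is 42%, within an estimated range of 22% to 60%.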

Compound 3, oral bioavailability: 9%
The estimate for compound 3 lay 33 percentage points above the measured number; the measured number lies below the stated range.
By their numbers in this assay, from the lowest: compounds 1 and 3 (each within the scatter of the next); then compound 2.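

Changing amino to methylamino adds only one carbon, yet it gives a number 41 percentage points lower from compound 2 to compound 3 (beyond the scatter) in this assay. At this nitrogen, then, even the smallest carbon group in place of a hydrogen can matter greatly for this read-out. Nothing available explains why the number falls.

From the compounds shown here alone, it remains open whether a longer chain such as ethyl on the same nitrogen would behave like methyl. A dimethylamino group, which keeps no hydrogen on that nitrogen, or an acetyl group there could also give a different answer.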